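Adding a Chloro Group to Compound 2

A few compounds are considered here, and "the series" means these few. Any claim that something is new, unique, unknown or untested is made for them only; others in the source may bear on it.

Compound 1 `COc1ccc(/C=C/C(=O)c2ccc(NC(=S)Nc3ccc(Cl)cc3)cc2)cc1`: 92%
Compound 2 `O=C(Nc1ccc(Cl)cc1)Nc1ccc(C(=O)/C=C/c2ccccc2)cc1`: 74.6%

In a functional assay on the whole organism (Abdomen, strain Swiss) for inhibition, with Mus musculus as the target, with a stated time of 30 min, at a dose of 10 mg/kg by the intraperitoneal route (on this read-out lower numbers stand for less inhibition and higher numbers for more inhibition at the one dose given (going by the name of the read-out)), compound 1 gives 92%, while compound 2 gives 74.6%, the lower of the two numbers, and the gap between them lies beyond the scatter. Compound 3 `O=C(Nc1ccc(Cl)cc1)Nc1ccc(C(=O)/C=C/c2ccc(Cl)cc2)cc1` differs from compound 2 by chloro in place of hydrogen on an aromatic carbon. Within the data shown here, no pair of measured compounds shows what such a change does here, so compound 3 is expected to shift only modestly upward, by about a number 5.4 percentage points higher from compound 2 to compound 3 (within the scatter), a step likely within the scatter. Compound 3 is therefore estimated at 80% in this assay, with a likely range from 65% to 92%.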

Compound 3, a percentage reported as inhibition, in the whole organism at one dose (the size of the read-out at that dose, not a potency): 51%
Beside the measured number, compound 3's estimate is 29 percentage points above it, and the stated range ends above it.
By their numbers in this assay, from the lowest: compound 3; then compound 2; then compound 1.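

In this assay, chloro in place of hydrogen on this aromatic carbon, para to a large group, turning phenyl into 4-chlorophenyl, gives a number 23.6 percentage points lower from compound 2 to compound 3 (beyond the scatter). Among these compounds, this is the first direct reading of this position, and it shows that the position is sensitive to this change, with the read-out falling when chloro enters. Nothing available accounts for this fall.

On these data alone, whether a fluoro, hydroxyl or amino group at this position would keep the read-out of compound 2 remains open. Compound 1 differs from compound 2 in more than one place, so it cannot settle this.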